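A few compounds are considered here, and "the series" means these few. Any claim that something is new, unique, unknown or untested is made for them only; others in the source may bear on it.

Of the compounds shown here, two have numbers so far. In a functional assay on CAL-27 cells (Homo sapiens) for cytotoxicity, read by resazurin assay (on this read-out lower numbers stand for stronger inhibition and higher numbers for weaker inhibition), compound 1 (`C#Cc1cccc(Nc2ncnc3ccc(NC(=O)c4ccc(C(=O)Nc5ccccc5N)s4)cc23)c1`) gives 410 nM and compound 2 (`C#Cc1cccc(Nc2ncnc3ccc(OCc4ccc(C(=O)Nc5ccccc5N)cc4)cc23)c1`) gives 610 nM as its result. These two values lie within the usual scatter of each other, so the numbers do not set compound 2 apart from compound 1. Compound 3 (`Nc1ccccc1NC(=O)c1ccc(COc2ccc3ncnc(Nc4cccc(Br)c4)c3c2)cc1`) keeps all of compound 2 except one group: bromo in place of ethynyl on an aromatic carbon, meta to a large group (bromo in place of ethynyl on an aromatic carbon). In other words, 3-ethynylphenyl becomes 3-bromophenyl. Going by the values given here, no measured pair shows what this swap does, so any forecast here is cautious. The expected step of a 1.0-fold lower number from compound 2 to compound 3 (0.01 log units; within the scatter) is estimated to stay within the scatter, with no direction favoured. In this assay the estimated value for compound 3 is 600 nM at the middle, with an expected range from 250 nM to 1500 nM for repeated measurements.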

Compound 3, half-maximal inhibitory concentration: 620 nM
The estimate for compound 3 lay 1.0-fold (0.01 log units) below the measured number; low and high end bracket the measured number.
By their numbers in this assay, from the lowest: compounds 1, 2 and 3 (each within the scatter of the next).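

In this assay, going by these compounds alone, bromo in place of ethynyl on an aromatic carbon gives a 1.0-fold higher number from compound 2 to compound 3 (0.01 log units; within the scatter) and provides the first reading of a change at this position. Here, meta to a large group, a single bromine atom and the two-carbon ethynyl group cannot be told apart by this read-out, even though the two groups differ in atom count and bonding. Nothing available explains why the swap leaves the number within the scatter.

On these data alone, whether an amine, a methoxy group or a carboxylic acid at the same place would also stay within the scatter remains open. As far as these compounds go, it is also open whether the same swap would behave this way in compound 1, whose linking chain differs from that of compound 2.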